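Benzoyl in Place of Trifluoromethylbenzyl on the Piperidine Nitrogen

The source may report more compounds than this note shows. Statements on the series, on what has been measured and on what is new or still open speak of the compounds shown alone.

Compound 1 `N#Cc1ccc(CN2CCC(NC(=O)COc3ccc4c(=O)cc(-c5ccccc5)oc4c3)CC2)cc1` gives 9300 nM in a functional assay on HepG2 cells (Homo sapiens) for cytotoxicity, read by MTT assay, with a stated time of 72 h; on this read-out higher numbers stand for weaker inhibition and lower numbers for stronger inhibition.
Compound 2 `O=C(COc1ccc2c(=O)cc(-c3ccccc3)oc2c1)NC1CCN(Cc2ccc(C(F)(F)F)cc2)CC1` gives 7200 nM in this assay.

Compound 2 cannot be set apart from compound 1 on these numbers, since the step of a 1.3-fold lower number from compound 1 to compound 2 (0.11 log units; within the scatter), a trifluoromethyl in place of a cyano on an aromatic carbon, stays within the scatter. Compound 3 `O=C(COc1ccc2c(=O)cc(-c3ccccc3)oc2c1)NC1CCN(C(=O)c2ccccc2)CC1` differs from compound 2 by benzoyl in place of 4-(trifluoromethyl)benzyl on an amine nitrogen in a ring. Among the measured compounds shown here, no measured step touches this nitrogen, so nothing in the data bears on the change. Compound 3 is therefore expected to land near compound 2, at an estimated 10000 nM in this assay, within a wide band from 4000 nM to 30000 nM. This estimate amounts to an expected step of a 1.4-fold higher number from compound 2 to compound 3 (0.14 log units; within the scatter).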

Compound 3, half-maximal inhibitory concentration: > 20000 nM
Compound 3 was reported as a limit; the forecaster's own chance of this, stated with the estimate: 10%; middle value at least 2.0-fold (0.30 log units) away from the limit.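

The group on this amine nitrogen in a ring does affect the result, whereas trifluoromethyl in place of cyano stayed within the scatter: benzoyl in place of the substituted benzyl gives an at least 2.7-fold higher number from compound 2 to compound 3 (0.44 log units; beyond the scatter), and likewise an at least 2.1-fold higher number from compound 1 to compound 3 (0.33 log units; beyond the scatter). Both steps point the same way, toward weaker inhibition. The value of compound 3 is a limit and not a number, so the full size of both steps stays unknown: the limit of > 20000 nM in this assay, at which 1 of the 3 values shown sits.

Compound 3 introduces the carbonyl and drops the ring substituent in one change, and the compounds shown do not separate the two. From the compounds shown here alone, how a plain benzyl or a 4-(trifluoromethyl)benzoyl on this nitrogen would read remains open.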